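Replacing the Aryl Group on the Amide Nitrogen

The source may report more compounds than this note shows. Statements on the series, on what has been measured and on what is new or still open speak of the compounds shown alone.

Compound 1 `Cc1ccccc1NC(=O)c1ccc2cccc(O)c2n1` was tested in an ADME assay on THP-1 cells (Homo sapiens) for cytotoxicity, read by WST assay, with a stated time of 24 h; on this read-out lower numbers stand for stronger inhibition and higher numbers for weaker inhibition. Compound 1 gives > 30000 nM, which is a limit of the assay rather than a number. Compound 2 `O=C(Nc1ccc(F)cc1)c1ccc2cccc(O)c2n1` gives > 30000 nM, likewise a limit. The step that the two limits leave unreadable from compound 1 to compound 2 therefore cannot be sized, because of the limit of > 30000 nM in this assay, at which 2 of the 2 values shown sit. Compound 3 `O=C(Nc1cccc(Cl)c1)c1ccc2cccc(O)c2n1` differs from compound 1 by 3-chlorophenyl in place of 2-methylphenyl on an amide-type nitrogen. Among the compounds with values here, the only neighbouring step is unreadable, so no shift beyond the scatter is expected in either direction. The estimated step that the limit leaves unreadable from compound 1 to compound 3 rests only on that shared limit. Compound 3 is expected at 40000 nM, within 20000 nM to 100000 nM, most likely again reported only as a limit.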

Compound 3, half-maximal inhibitory concentration: > 30000 nM
Compound 3: a limit, no number; the forecaster's own chance of this, stated with the estimate: 80%; the middle value does not contradict the limit.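

Within the data shown here, no step among compound 1, compound 2 and compound 3 can be read, since each value is only a limit: the limit of > 30000 nM in this assay, at which 3 of the 3 values shown sit.

The compounds shown leave open how strongly each one acts in this assay and whether changing the aryl group on the amide nitrogen matters there.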